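This account rests on a few compounds, and the source may have more. Where it says the series, first, only, none or still open, it means among the compounds named here.

Working notes on the series. Of the compounds shown here, three have numbers so far: compound 1 `Fc1cccc(F)c1C#Cc1ccc2c(Cl)ccnc2c1`, compound 2 `Fc1cccc(F)c1C#Cc1ccc2[nH]ccc2c1` and compound 3 `CN(C)c1ccc2cc(C#Cc3c(F)cccc3F)ccc2n1`. In a functional assay on LS174T cells (Homo sapiens) for inhibition, with a stated time of 4 days, tested at 1 uM (a lower number here means a weaker effect, a higher number a stronger effect of the compound at the concentration tested), compound 2 gives 52.9%, the highest of the three; compound 1 gives 23.1%, a gap beyond the scatter, and compound 3 gives 2%, the furthest away and also beyond the scatter. The next compound, compound 4 `Cn1ccc2cc(C#Cc3c(F)cccc3F)ccc21`, differs from compound 2 in one place: methyl in place of hydrogen on an aromatic nitrogen. Among the compounds with values here, no measured pair shows this change, so the numbers at hand do not tell its effect. The expectation for compound 4 in this assay is a small loss, or none beyond the scatter. Compound 4 is accordingly estimated at 40%, within a range from 15% to 65%. The estimated step is a number 12.9 percentage points lower from compound 2 to compound 4 (beyond the scatter).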

Compound 4, a percentage reported as inhibition, at one concentration (the size of the read-out at that concentration, not a potency): 77.7%
Compound 4: middle estimate off by 37.7 percentage points, on the low side, outside the stated range (above it).
By their numbers in this assay, from the lowest: compound 3; then compound 1; then compound 2; then compound 4.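

Methyl in place of hydrogen on the aromatic nitrogen gives a number 24.8 percentage points higher from compound 2 to compound 4 (beyond the scatter) in this assay. The hydrogen on this nitrogen is therefore not needed for the inhibition seen at the concentration tested, and this position accepts a methyl with a gain, though on the evidence of this single pair only. Nothing at hand accounts for the gain.

Open, going by these compounds, is whether a longer chain such as propyl on this nitrogen keeps the gain. Also open, on these data alone, is how a chain ending in an amine or a carboxylic acid behaves at the same position.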